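A Single Fluoro Step from Compound 2

The compounds below may be only part of what the source reports. "The series", "measured", "known", "first", "only" and "open" are said of these compounds alone.

Values measured in a functional assay on NCI-H460 cells (Homo sapiens) for antiproliferative activity, with a stated time of 72 h (a lower number here means a stronger inhibitor, a higher number a weaker inhibitor), are these:

Compound 1 (`C=C1C=CC(=O)[C@@H]2[C@H](Cc3ccc(OCOC)c(F)c3)CC[C@H]12`) gives 106 nM
Compound 2 (`C=C1C=CC(=O)[C@@H]2[C@H](Cc3ccc(O)cc3)CC[C@H]12`) gives 77.6 nM

Going by the values given here, compound 2 holds one of only two numbers, and it lies within the scatter of compound 1. Compound 3 (`C=C1C=CC(=O)[C@@H]2[C@H](Cc3ccc(O)c(F)c3)CC[C@H]12`) differs from compound 2 in one place (fluoro in place of hydrogen on an aromatic carbon): fluoro in place of hydrogen on an aromatic carbon, ortho to a hydroxy group. Among the compounds with values here, no measured pair shows this change alone, so no step beyond the scatter is expected in this assay for it. Compound 1, which also carries fluoro, stands at (106 nM) and gives no sign of a large shift. The expected change is small (a 1.1-fold lower number from compound 2 to compound 3 (0.04 log units; within the scatter)). For compound 3 the estimate is (70 nM) with 30 nM to 170 nM as the expected range.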

Compound 3, half-maximal inhibitory concentration: 229 nM
Compound 3: middle estimate off by 3.3-fold (0.51 log units), on the low side; the whole stated range lies below it.
By their numbers in this assay, from the lowest: compounds 2 and 1 (each within the scatter of the next); then compound 3.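

In this assay, fluoro on this aromatic carbon, ortho to a hydroxy group, is not a silent change: it gives a 3.0-fold higher number from compound 2 to compound 3 (0.47 log units; beyond the scatter). The oxygen matters as well, since with fluoro kept in place, hydrogen in place of methoxymethyl gives a 2.2-fold higher number from compound 1 to compound 3 (0.33 log units; beyond the scatter). Nothing measured here explains either rise.

On these data alone, whether chloro or a methyl group on the same carbon would raise the number as fluoro does remains open. So does whether the fluoro step holds when the oxygen carries methoxymethyl or a simple methyl group.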